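Swapping isobutyl(methyl)sulfamoyl for methylsulfonyl on compound 3

A few compounds are considered here, and "the series" means these few. Any claim that something is new, unique, unknown or untested is made for them only; others in the source may bear on it.

Among the measured compounds shown here, in an in vitro ADME assay on microsomes from liver (Homo sapiens) for metabolic stability, read by LC-MS, tested at 1 uM (a lower number here means slower removal, a higher number faster removal of the compound), compound 3 `Cc1ccc(S(=O)(=O)N(C)CC(C)C)cc1C#Cc1cc(Cl)ccc1OCC(=O)O` gives 79 mL.min-1.g-1, the only true number among the three compounds measured and the fastest removal of them. Compound 1 `Cc1ccc(S(=O)(=O)N(C)C(C)C)cc1C#Cc1cc(Cl)ccc1OCC(=O)O` gives < 10 mL.min-1.g-1, which is a limit of this assay and not a number. Compound 2 `Cc1ccc(S(=O)(=O)N2CCOCC2)cc1C#Cc1cc(Cl)ccc1OCC(=O)O` gives < 10 mL.min-1.g-1, which is likewise a limit.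

Compound 4 `Cc1ccc(S(C)(=O)=O)cc1C#Cc1cc(Cl)ccc1OCC(=O)O` has not been measured. It differs from compound 3 as follows: methyl in place of isobutyl(methyl)amino on a sulfonyl sulfur.

For the measured compounds named here, no measured step makes this exact change, but two steps alter the same spot on the sulfonyl sulfur. They are an at least 7.9-fold higher number from compound 1 to compound 3 (0.89 log units; beyond the scatter) and an at least 7.9-fold higher number from compound 2 to compound 3 (0.89 log units; beyond the scatter), both beyond the scatter. Among these three compounds, only compound 3 carries isobutyl(methyl)amino, and compound 4 loses it, so a clear fall is expected. The expected change is a 6.6-fold lower number from compound 3 to compound 4 (0.82 log units; beyond the scatter). For compound 4 the estimated value is 12 mL.min-1.g-1, with an expected range from 5 mL.min-1.g-1 to 35 mL.min-1.g-1.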

Compound 4, intrinsic clearance in microsomes: 14 mL.min-1.g-1
The estimate for compound 4 lay 1.2-fold (0.07 log units) below the measured number; the range from low to high includes it.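

In this assay, every group on the sulfonyl sulfur so far carried a nitrogen, and the methyl now shows that the number also stays low with no nitrogen there, as the change brings a 5.6-fold lower number from compound 3 to compound 4 (0.75 log units; beyond the scatter). Against the two other compounds, the readings are an at least 1.4-fold higher number from compound 2 to compound 4 (0.14 log units; that floor lies within the scatter) and an at least 1.4-fold higher number from compound 1 to compound 4 (0.14 log units; that floor lies within the scatter), so the methyl cannot be ranked against either amine. Those two steps give only a floor because their starting values are a limit and not a number: the limit of < 10 mL.min-1.g-1 in this assay, at which 2 of the 4 values shown sit.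

What the compounds shown leave open is whether the high number of compound 3 depends on the branched isobutyl group or would also appear with a straight butyl chain on the sulfonamide nitrogen. From the compounds shown here alone, an ethyl or a longer chain in place of the methyl on the sulfonyl sulfur also remains unexplored.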